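Moving the chlorine on the arylpiperazine of compound 3

The source may hold more compounds than are shown below. What is called first, only, known or untested is meant among the compounds shown, and "the series" means these compounds.

Compound 1, `CCC1(CCCCN2CCN(c3ccc(F)c(Cl)c3)CC2)C(=O)Nc2ccccc21`: > 20 mg/kg
Compound 2, `O=C1Nc2ccccc2C1CCCCN1CCN(c2cccc(Cl)c2)CC1`: < 5 mg/kg
Compound 3, `CCC1(CCCCN2CCN(c3ccc(Cl)cc3)CC2)C(=O)Nc2ccccc21`: 10 mg/kg

In a functional assay on the whole organism (strain Wistar) with Rattus norvegicus as the target, with a stated time of 5 min (a higher number here means that more compound is needed for the effect, a lower number that less compound is needed), compound 3 gives 10 mg/kg, the only figure among the three that is a number. For compound 1 the value > 20 mg/kg is a limit of the assay, as recorded at the limit of > 20 mg/kg in this assay, at which 1 of the 3 values shown sits. For compound 2 the value < 5 mg/kg is likewise a limit, recorded at the limit of < 5 mg/kg in this assay, at which 1 of the 3 values shown sits. Going by the values given here, the one measured step, an at least 2.0-fold lower number from compound 1 to compound 3 (0.30 log units; that floor lies within the scatter), is a change of the aryl group on the piperazine, and its floor lies within the scatter.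

Compound 4, `CCC1(CCCCN2CCN(c3cccc(Cl)c3)CC2)C(=O)Nc2ccccc21`, differs from compound 3 by 3-chlorophenyl in place of 4-chlorophenyl on an amine nitrogen in a ring. Among the compounds with values here, no measured step covers this exact change; the step from compound 1 to compound 3 also moved substituents on the same aryl group and gave a lower number, while compound 2, which also carries a 3-chlorophenyl but lacks the ethyl group, reached only a limit. Compound 4 is therefore expected to show a small step, a 1.4-fold lower number from compound 3 to compound 4 (0.15 log units; within the scatter), toward a lower number, no larger than the scatter with confidence. Compound 4 is estimated at 7 mg/kg, within 3 mg/kg to 20 mg/kg.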

Compound 4, minimum effective dose: > 20 mg/kg
Compound 4 gave a limit, no number; the forecaster's own chance of this, stated with the estimate: 30%; at least 2.8-fold (0.45 log units) between middle value and limit.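

Taking 3-chlorophenyl in place of 4-chlorophenyl in this assay gives an at least 2.0-fold higher number from compound 3 to compound 4 (0.30 log units; that floor lies within the scatter), so this change on the amine nitrogen in a ring shows no sign of a lower number, though its floor cannot be told from the scatter. Going by these compounds alone, the clearer finding concerns the ethyl group: with 3-chlorophenyl held fixed, ethyl in place of hydrogen on a saturated ring carbon gives an at least 4.0-fold higher number from compound 2 to compound 4 (0.60 log units; beyond the scatter), the only new step that is beyond the scatter. The step between compound 1 and compound 4 cannot be read, as both values are limits: the limit of > 20 mg/kg in this assay, at which 2 of the 4 values shown sit.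

As far as these compounds go, whether a methyl group or a longer chain in place of the ethyl would act in the same way remains open. So does whether hydrogen in place of ethyl would give a similar step alongside 4-chlorophenyl.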